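Swapping an aryl amide for an aryl urea

This account rests on a few compounds, and the source may have more. Where it says the series, first, only, none or still open, it means among the compounds named here.

Compound 3 `COc1cc(-c2nn(-c3cccc(NC(=O)c4ccc(Cl)c(C(F)(F)F)c4)c3)cc2-c2ccncc2)ccc1Cl` stands at a limit in a functional assay on OVCAR-8 cells (Homo sapiens) for inhibition, read by sulforhodamine B assay, with a stated time of 48 h; a lower number here means a stronger inhibitor of growth, a higher number a weaker inhibitor of growth: compound 3 gives > 32500 nM, which is a limit of the assay (the limit of > 32500 nM in this assay, at which 1 of the 3 values shown sits). Compound 4 `COc1cc(-c2nn(-c3cccc(NC(=O)Nc4ccc(Cl)c(C(F)(F)F)c4)c3)cc2-c2ccncc2)ccc1Cl` differs from it only in (4-chloro-3-(trifluoromethyl)phenyl)amino in place of 4-chloro-3-(trifluoromethyl)phenyl on a carbonyl carbon. A swap of the same kind has been seen once before. Compound 1 `COc1cc(-c2nn(-c3cccc(NC(=O)c4cccc(C(F)(F)F)c4)c3)cc2-c2ccncc2)ccc1Cl` gives > 50000 nM, also a limit (the limit of > 50000 nM in this assay, at which 1 of the 3 values shown sits). Its urea partner compound 2 `COc1cc(-c2nn(-c3cccc(NC(=O)Nc4ccc(Cl)c(Cl)c4)c3)cc2-c2ccncc2)ccc1Cl` gives 3610 nM, and the step of an at least 13-fold lower number from compound 1 to compound 2 (1.14 log units; beyond the scatter) is large, while the reverse step of an at least 9.0-fold higher number from compound 2 to compound 3 (0.95 log units; beyond the scatter) is at least modest. The step that the two limits leave unreadable from compound 1 to compound 3 cannot be sized. By analogy the number for compound 4 is expected to drop, an at least 9.2-fold lower number from compound 3 to compound 4 (0.96 log units; beyond the scatter). Compound 4 is therefore estimated at 3500 nM, in a range from 1000 nM to 15000 nM.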

Compound 4, concentration for total growth inhibition: 5870 nM
Compound 4: the middle estimate sits 1.7-fold (0.22 log units) below what was measured, and the stated range covers the measured number.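

Adding only the amino nitrogen on the carbonyl carbon, with the aryl group unchanged, gives an at least 5.5-fold lower number from compound 3 to compound 4 (0.74 log units; beyond the scatter), so the urea effect no longer rests on a pair that also differs in its aryl group. The amide compound 1 likewise stands apart from the urea, with an at least 8.5-fold lower number from compound 1 to compound 4 (0.93 log units; beyond the scatter); both steps start from a limit, so each gives only a minimum. Between the ureas, a 1.6-fold higher number from compound 2 to compound 4 (0.21 log units; within the scatter) means trifluoromethyl and chloro on that aromatic carbon cannot be told apart here.

On these data alone, it remains open whether the lower number would survive a methyl on the new nitrogen, or an oxygen in its place, as in a carbamate.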